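Four analogues, one chloro substitution, cytotoxicity notes

A few compounds are considered here, and "the series" means these few. Any claim that something is new, unique, unknown or untested is made for them only; others in the source may bear on it.

Compound 1 `ClCc1ccc(Cn2cnc3c(Cl)ncnc32)cc1` and compound 3 `ClCc1ccc(Cn2cnc3c(Cl)nc(Cl)nc32)cc1` share a core and differ by chloro in place of hydrogen on an aromatic carbon. In a functional assay on K562 cells (Homo sapiens) for cytotoxicity, read by sulforhodamine B assay, with a stated time of 48 h (on this read-out higher numbers stand for lower toxicity in this test and lower numbers for higher toxicity in this test), compound 1 gives > 100000 nM, which is a limit of the assay and not a number. In this assay compound 3 gives > 100000 nM, likewise only a limit. The step that the two limits leave unreadable from compound 1 to compound 3 therefore has no readable size; the limit of > 100000 nM in this assay, at which 3 of the 3 values shown sit, is all the evidence there is. Compound 2 `ClCc1cccc(Cn2cnc3ncnc(Cl)c32)c1` has the same atoms as compound 1 joined differently; the difference between the two cores is not broken down here. In this assay compound 2 gives > 100000 nM, again a limit. Compound 4 `ClCc1cccc(Cn2cnc3nc(Cl)nc(Cl)c32)c1` stands to compound 2 as compound 3 stands to compound 1, the change being (chloro in place of hydrogen on an aromatic carbon); the place is described in the same words, so it is the same change. The step from compound 2 to compound 4 is expected to be a step that the limit leaves unreadable from compound 2 to compound 4, an expectation that rests on the step that the two limits leave unreadable from compound 1 to compound 3 having no readable size. Compound 4 is accordingly estimated at 120000 nM, most probably to be reported as a limit once more.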

Compound 4, concentration lethal to 50% of the cells: 5240 nM
Estimate against measurement, compound 4: 23-fold (1.36 log units) above; measured number outside the range, below it.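

Compound 2 gives > 100000 nM in this assay, which is a limit of the assay and not a number. On the core of compound 2, chloro in place of hydrogen on an aromatic carbon gives an at least 19-fold lower number from compound 2 to compound 4 (1.28 log units; beyond the scatter), so the change has a clear effect on this read-out on that core, towards higher toxicity in this test. The matching step on the core of compound 1 cannot be read, so the data show neither that the change carries from one core to the other nor that it fails to, and the one clear step stands alone: the limit of > 100000 nM in this assay, at which 3 of the 4 values shown sit.

Going by these compounds, it remains open whether an amine or a methoxy group on the same aromatic carbon, between two ring nitrogen atoms, would move the number on the core of compound 2 as chloro does. On these data alone, it also remains open whether any replacement at that place would bring the core of compound 1 off the limit.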